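The source may report more compounds than this note shows. Statements on the series, on what has been measured and on what is new or still open speak of the compounds shown alone.

The study contains two measured compounds. Compound 1 `CCCS(=O)(=O)c1cc(C#Cc2cc(Cl)ccc2OCC(=O)O)c(C)cc1NC(C)=O` gives 1.3 nM in an assay on CHO cells for displacement of a labelled ligand from prostaglandin D2 receptor 2 (Homo sapiens), read by scintillation counting; on this read-out lower numbers stand for stronger inhibition and higher numbers for weaker inhibition. Compound 2 `O=C(O)COc1cc(F)ccc1C#Cc1ccccc1Cl` gives 4780 nM in this assay, the highest of the two numbers shown, and the gap between compound 1 and compound 2 lies far beyond the scatter of the method. Among the compounds with values here, no pair of measured compounds here differs in only one place, so no single-change step has been measured. Compound 3 `O=C(O)COc1ccccc1C#Cc1ccccc1Cl` is the unmeasured compound, and it differs from compound 2 by hydrogen in place of fluoro on an aromatic carbon, a hydrogen in place of fluoro on an aromatic carbon. Within the data shown here, with no comparable step recorded among the measured compounds, the author expects the step from compound 2 to compound 3 to stay within the usual scatter or to go slightly toward a higher number, a 1.3-fold higher number from compound 2 to compound 3 (0.10 log units; within the scatter). Compound 3 is therefore estimated at 6000 nM, with a range from 2000 nM to 20000 nM.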

Compound 3, inhibition constant: 747 nM
For compound 3 the middle estimate is 8.0-fold (0.90 log units) above the measured one; the measured number lies below the stated range.
By their numbers in this assay, from the lowest: compound 1; then compound 3; then compound 2.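

In this assay, within the data shown here, putting hydrogen in place of fluoro on an aromatic carbon gives a 6.4-fold lower number from compound 2 to compound 3 (0.81 log units; beyond the scatter) and so counts as a real change, the first single-change step that can be read. This position, meta to the carboxymethoxy group and para to the group of 9 heavy atoms, is therefore not indifferent to its substituent, and within this pair the compound carrying hydrogen there gives the lower number. Nothing shown here accounts for the size or direction of this step.

On these data alone, whether another group at this position, such as chloro, methoxy or an amine, would lower the number further remains open. As far as these compounds go, it is also open whether the same change would give a similar step on the core of compound 1, where the other aromatic ring carries more substituents.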